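The source may hold more compounds than are shown below. What is called first, only, known or untested is meant among the compounds shown, and "the series" means these compounds.

In a functional assay on G-361 cells (Homo sapiens) for antiproliferative activity, with a stated time of 72 h (on this read-out lower numbers stand for stronger inhibition and higher numbers for weaker inhibition), compound 2 `OC[C@H]1O[C@@H](n2cnc3c(NCc4ccc(Br)cc4)ncnc32)[C@H](O)[C@@H]1O` reaches only a limit of the assay, reported as > 166000 nM. Compound 3 `OC[C@H]1O[C@@H](n2cnc3c(NCc4c(F)ccc(F)c4F)ncnc32)[C@H](O)[C@@H]1O` likewise stops at a limit, > 166000 nM. The step that the two limits leave unreadable from compound 2 to compound 3 therefore has no readable size. Compound 1 `OC[C@H]1O[C@@H](n2cnc3c(NCc4ccccc4Cl)ncnc32)[C@H](O)[C@@H]1O` has no result in this assay, "not determined" (no result reported). Compound 2 thus stands where the limit of > 166000 nM in this assay, at which 2 of the 3 values shown sit, places it, with no shown value that separates it from any other compound. Compound 4 `OC[C@H]1O[C@@H](n2cnc3c(NCc4cc(O)cc(O)c4)ncnc32)[C@H](O)[C@@H]1O` differs from compound 2 by 3,5-dihydroxyphenyl in place of 4-bromophenyl on a saturated chain carbon bound to a nitrogen on an aromatic ring. No measured step runs from 4-bromophenyl to 3,5-dihydroxyphenyl, so the size of this change cannot be read from the shown compounds. A move from the limit toward a measurable number is nonetheless expected, and the step expected in this assay is an at least 8.3-fold lower number from compound 2 to compound 4 (0.91 log units; beyond the scatter). Compound 4 is estimated at 20000 nM, within 3000 nM to 166000 nM.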

Compound 4, half-maximal inhibitory concentration: > 166000 nM
Compound 4 ended at the assay's limit; the forecaster's own chance of this, stated with the estimate: 35%; middle value at least 8.3-fold (0.91 log units) from the limit.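

In this assay, among these compounds, compound 2, compound 3 and compound 4 all stop at a limit, so no step among them can be read. The compounds shown leave open whether any group in place of 4-bromobenzyl would give a measurable number.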